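Replacing the dichlorophenyl arm of compound 1

The source may report more compounds than this note shows. Statements on the series, on what has been measured and on what is new or still open speak of the compounds shown alone.

Measured in an ADME assay on Caco-2 cells (Homo sapiens) for permeability, in the apical to basolateral direction, with a stated time of 90 min, tested at 10 uM; a lower number here means that the compound crosses the layer more slowly, a higher number that the compound crosses the layer faster:
Compound 1 `O=C(NC[C@@H]1[C@H]2CN(C(=O)CCc3cc(Cl)cc(Cl)c3)C[C@@H]12)c1ccc2[nH]c(=O)oc2c1` gives 18 10^-6 cm/s
Compound 2 `O=C(NC[C@@H]1[C@H]2CN(C(=O)OCc3cc(C(F)(F)F)cc(C(F)(F)F)c3)C[C@@H]12)c1ccc2[nH]c(=O)oc2c1` gives 108 10^-6 cm/s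

Of these two compounds, compound 1 stands lowest in this assay, and its gap to compound 2 lies beyond the usual scatter. Compound 3 `Cc1cc(COC(=O)N2C[C@@H]3[C@@H](CNC(=O)c4ccc5[nH]c(=O)oc5c4)[C@@H]3C2)no1` has not yet been measured. It keeps the core of compound 1 but carries (5-methyl-1,2-oxazol-3-yl)methoxy in place of 2-(3,5-dichlorophenyl)ethyl on a carbonyl carbon. The new group sits on the same carbonyl carbon, whose other neighbour is an amide-type nitrogen in a ring.

Among the measured compounds shown here, the two measured compounds differ in more than one place, and no measured step isolates this change. With so little to go on, the expectation stays nearer to compound 1 at 18 10^-6 cm/s than to compound 2 at 108 10^-6 cm/s, and the range is kept wide. The expected change is a 1.4-fold higher number from compound 1 to compound 3 (0.14 log units; within the scatter), a small rise that stays within the usual scatter. For compound 3 the estimated value is 25 10^-6 cm/s, with an expected range of 8 10^-6 cm/s to 70 10^-6 cm/s.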

Compound 3, apparent permeability: 2 10^-6 cm/s
The estimate for compound 3 lay 13-fold (1.10 log units) above the measured number; the measured number lies below the stated range.
By their numbers in this assay, from the lowest: compound 3; then compound 1; then compound 2.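

In this assay, among the compounds shown here, the exchange on the carbonyl carbon gives a 9.0-fold lower number from compound 1 to compound 3 (0.95 log units; beyond the scatter), the first measured change here that is confined to one place, so this position clearly bears on the read-out. The swap of 2-(3,5-dichlorophenyl)ethyl for (5-methyl-1,2-oxazol-3-yl)methoxy alters several things at once: a six-membered aromatic ring of carbon only gives way to a five-membered aromatic ring with 2 hetero atoms, and the group goes from 0 hydrogen-bond acceptors to 3, so this one step cannot assign the fall to any of these features. Nothing measured on these compounds accounts for the fall.

The compounds shown leave open whether the fall follows the new ring or the oxygen that now joins the arm to the carbonyl carbon. A 3,5-dichlorobenzyloxy group on the same carbonyl carbon would keep the dichlorophenyl ring while taking on that oxygen, and a 2-(5-methyl-1,2-oxazol-3-yl)ethyl group would do the reverse, so that either one could separate the two parts of this change.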